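A few compounds are considered here, and "the series" means these few. Any claim that something is new, unique, unknown or untested is made for them only; others in the source may bear on it.

Values in an ADME assay on HepG2 cells (Homo sapiens) for cytotoxicity, read by MTT assay, with a stated time of 72 h; on this read-out higher numbers stand for lower toxicity in this test and lower numbers for higher toxicity in this test:
- compound 1 `Nc1sc2c(c1-c1nc3ccccc3s1)CCCC2`: 163 ug/mL
- compound 2 `Fc1ccc(/C=N/c2sc3c(c2-c2nc4ccccc4s2)CCCC3)cc1`: 324 ug/mL
- compound 3 `Fc1ccccc1/C=N/c1sc2c(c1-c1nc3ccccc3s1)CCCC2`: 398 ug/mL

Compound 3 lies within the scatter of compound 2, and the two are separated by a 1.2-fold higher number from compound 2 to compound 3 (0.09 log units; within the scatter). Against compound 1 the picture is a 2.4-fold higher number from compound 1 to compound 3 (0.39 log units; beyond the scatter), while the matching comparison gives a 2.0-fold higher number from compound 1 to compound 2 (0.30 log units; within the scatter).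

Compound 4 `C(=C/c1ccccc1)\C=N\c1sc2c(c1-c1nc3ccccc3s1)CCCC2` has not yet been measured and differs from compound 3 as follows: 2-phenylethenyl in place of 2-fluorophenyl on a carbon with a double bond to nitrogen. Here 2-phenylethenyl stands in place of 2-fluorophenyl on a carbon with a double bond to nitrogen.

Going by the values given here, the closest evidence is the only measured change at this carbon, the swap of 4-fluorophenyl for 2-fluorophenyl, which gave a 1.2-fold higher number from compound 2 to compound 3 (0.09 log units; within the scatter). The two larger steps replace a nitrogen atom on an aromatic carbon and bear on this change only indirectly. Among the compounds with values here, no measured compound carries 2-phenylethenyl, so the expectation remains loose.

The expected change is a 1.1-fold lower number from compound 3 to compound 4 (0.06 log units; within the scatter), and no step beyond the scatter is expected. For compound 4 the estimated value is 350 ug/mL, with an expected range from 180 ug/mL to 650 ug/mL.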

Compound 4, half-maximal cytotoxic concentration: 467 ug/mL
For compound 4 the middle estimate is 1.3-fold (0.13 log units) below the measured one; the measured number falls inside the stated range.
By their numbers in this assay, from the lowest: compounds 1, 2, 3 and 4 (each within the scatter of the next, the first and the last beyond it).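

In this assay the carbon with a double bond to nitrogen also takes 2-phenylethenyl, a group with no fluorine and with a double bond outside aromatic rings; the change gives a 1.2-fold higher number from compound 3 to compound 4 (0.07 log units; within the scatter). Measured against the other fluorinated member, it gives a 1.4-fold higher number from compound 2 to compound 4 (0.16 log units; within the scatter). The data give no property or other measurement that could account for how these groups read in this test.

Still open, from the compounds shown here alone, is whether a group at this carbon with no aromatic ring, such as a longer alkyl chain, would remain within the scatter of compound 2, compound 3 and compound 4. Going by these compounds, it is equally open whether an amine or a carboxylic acid on the phenyl ring of the 2-phenylethenyl group would leave the number in this assay in the same range.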